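The source may hold more compounds than are shown below. What is called first, only, known or untested is meant among the compounds shown, and "the series" means these compounds.

Working notes on the series. Compound 1 `Nc1cc(N)c2nc(-c3ccccc3)c(Oc3ccc(F)cc3)nc2c1` carries a 4-fluorophenoxy group on the shared core; in a functional assay on SK-OV-3 cells (Homo sapiens) for inhibition, read by sulforhodamine B assay, with a stated time of 48 h (a higher number here means a weaker inhibitor of growth, a lower number a stronger inhibitor of growth), compound 1 gives 20900 nM, the highest of the two numbers in hand. Compound 2 `COc1cc(CNc2nc3cc(N)cc(N)c3nc2-c2ccccc2)cc(OC)c1OC` gives 5370 nM in this assay, a gap to compound 1 that is beyond the usual scatter. Compound 3 `CCOC(=O)[C@H](CCC(=O)O)NC(=O)c1ccc(CNc2nc3cc(N)cc(N)c3nc2-c2ccccc2)cc1` returns only < 100000 nM, a limit of this assay rather than a number; (the limit of < 100000 nM in this assay, at which 1 of the 3 values shown sits). Compound 4 `COc1ccc(Sc2nc3cc(N)cc(N)c3nc2-c2ccccc2)cc1` differs from compound 1 by (4-methoxyphenyl)sulfanyl in place of 4-fluorophenoxy on an aromatic carbon. Among the compounds with values here, no measured pair shows this change, so its size is open; a small drop in the number, not clearly beyond the scatter, is expected and set at a 1.5-fold lower number from compound 1 to compound 4 (0.17 log units; within the scatter). Compound 4 is expected to give 14000 nM in this assay, within 5000 nM to 45000 nM.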

Compound 4, concentration for 50% growth inhibition: 33100 nM
Beside the measured number, compound 4's estimate is 2.4-fold (0.37 log units) below it, and the stated range covers the measured number.
By their numbers in this assay, from the lowest: compound 2; then compounds 1 and 4 (each within the scatter of the next).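

In this assay, the step at this position gives a 1.6-fold higher number from compound 1 to compound 4 (0.20 log units; within the scatter), with (4-methoxyphenyl)sulfanyl in place of 4-fluorophenoxy. Within the data shown here, this is the first step read on this aromatic carbon next to the ring nitrogen, and the two groups are not separated by the assay. Nothing in hand gives a cause for the size of this step.

The step changes the linking atom and the ring substituent together, and a 4-fluorophenylsulfanyl group would be needed to part the two. From the compounds shown here alone, how a morpholine ring at this position would read remains open.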